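This account rests on a few compounds, and the source may have more. Where it says the series, first, only, none or still open, it means among the compounds named here.

Four compounds share one core; two of them carry a 3-chlorophenyl on an aromatic nitrogen and two a 4-chlorophenyl. Compound 1 `O=c1[nH]cc(S(=O)(=O)Nc2cccc(-c3cn(-c4cccc(Cl)c4)nn3)c2)c(=O)[nH]1` in an ADME assay on GES1 cells (Homo sapiens) for cytotoxicity, read by MTT assay, with a stated time of 24 h (on this read-out lower numbers stand for higher toxicity in this test and higher numbers for lower toxicity in this test), gives 26200 nM, and compound 2 `O=c1[nH]cc(S(=O)(=O)Nc2cccc(-c3cn(-c4ccc(Cl)cc4)nn3)c2)c(=O)[nH]1` gives 11300 nM. The change between them is 4-chlorophenyl in place of 3-chlorophenyl on an aromatic nitrogen, and it made a 2.3-fold lower number from compound 1 to compound 2 (0.37 log units; beyond the scatter). Compound 3 `O=c1[nH]cc(S(=O)(=O)Nc2ccc(-c3cn(-c4cccc(Cl)c4)nn3)cc2)c(=O)[nH]1` gives 7570 nM in this assay; how its core differs from that of compound 1 is not broken down here. Compound 4 `O=c1[nH]cc(S(=O)(=O)Nc2ccc(-c3cn(-c4ccc(Cl)cc4)nn3)cc2)c(=O)[nH]1` is not yet measured; it differs from compound 3 by 4-chlorophenyl in place of 3-chlorophenyl on an aromatic nitrogen, the same change as that from compound 1 to compound 2, at the same place. Because a 2.3-fold lower number from compound 1 to compound 2 (0.37 log units; beyond the scatter) was seen once, a step of similar size is expected for compound 4, namely a 1.9-fold lower number from compound 3 to compound 4 (0.28 log units; within the scatter). Compound 4 is estimated at 4000 nM, between 1500 nM and 10000 nM.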

Compound 4, half-maximal cytotoxic concentration: 23300 nM
The estimate for compound 4 lay 5.8-fold (0.77 log units) below the measured number; measured number outside the range, above it.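

On the core of compound 3, 4-chlorophenyl in place of 3-chlorophenyl gave a 3.1-fold higher number from compound 3 to compound 4 (0.49 log units; beyond the scatter). In this assay, within the data shown here, the same change therefore does not carry from one core to the other, and its direction reverses: the same change on two cores in this assay, a 2.3-fold lower number (0.37 log units; beyond the scatter) from compound 1 to compound 2 and a 3.1-fold higher number (0.49 log units; beyond the scatter) from compound 3 to compound 4, 7.1-fold (0.85 log units) apart, beyond the scatter of two such steps With only one pair on each core, this shows that the outcome of the change depends on the core within these four compounds, but it does not show why, or what the change would do on any further core.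

Going by these compounds, it remains open whether a phenyl carrying a methoxy group or a nitrile instead of chlorine would show the same reversal between the two cores. A plain phenyl, without chlorine, also remains an open comparison.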